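Furan for Thiophene on a Shared Core: Compound 4

This account rests on a few compounds, and the source may have more. Where it says the series, first, only, none or still open, it means among the compounds named here.

In a functional assay on A549 cells (Homo sapiens) for cytotoxicity, read by MTT assay, with a stated time of 48 h (on this read-out lower numbers stand for stronger inhibition and higher numbers for weaker inhibition), compound 1 `COc1cc(C(=O)C2Sc3nnc(-c4cc(OC)c(OC)c(OC)c4)n3NC2c2ccco2)cc(OC)c1OC` gives 48300 nM. Compound 2 `COc1cc(-c2nnc3n2NC(c2cccs2)C(C(=O)c2ccccc2)S3)cc(OC)c1OC` gives 69400 nM in this assay; these two numbers lie within the scatter of each other. Compound 3 `COc1cc(C(=O)C2Sc3nnc(-c4cc(OC)c(OC)c(OC)c4)n3NC2c2cccs2)cc(OC)c1OC` returns only a limit of the assay, > 100000 nM. Compound 3 differs from compound 2 by phenyl in place of 3,4,5-trimethoxyphenyl on a carbonyl carbon, and an at least 1.4-fold higher number from compound 2 to compound 3 (0.15 log units; that floor lies within the scatter). Compound 1 differs from compound 3 by furan-2-yl in place of thiophen-2-yl on a saturated ring carbon, and an at least 2.0-fold lower number from compound 3 to compound 1 (0.31 log units; beyond the scatter); this step is only a floor because compound 3 sits at the limit of > 100000 nM in this assay, at which 1 of the 3 values shown sits.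

Compound 4 `COc1cc(-c2nnc3n2NC(c2ccco2)C(C(=O)c2ccccc2)S3)cc(OC)c1OC` is not yet measured and differs from compound 2 by furan-2-yl in place of thiophen-2-yl on a saturated ring carbon. It is the same kind of change as that from compound 3 to compound 1, though around the place the neighbouring ring atom bears a benzoyl group (8 heavy atoms) in one pair and a large group in the other. Resting on the earlier step from compound 3 to compound 1, compound 4 is expected to show a 2.0-fold lower number from compound 2 to compound 4 (0.30 log units; within the scatter). The estimate for compound 4 in this assay is 35000 nM, with a likely range from 15000 nM to 80000 nM.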

Compound 4, half-maximal inhibitory concentration: 33400 nM
For compound 4 the middle estimate is 1.0-fold (0.02 log units) above the measured one; measured number inside the range.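

In this assay, furan-2-yl in place of thiophen-2-yl on a saturated ring carbon gives a 2.1-fold lower number from compound 2 to compound 4 (0.32 log units; beyond the scatter), so the change carries to the second core in the same direction: the same change on two cores in this assay, an at least 2.0-fold lower number (0.31 log units; beyond the scatter) from compound 3 to compound 1 and a 2.1-fold lower number (0.32 log units; beyond the scatter) from compound 2 to compound 4; the limit leaves it open whether they differ. Whether its size is the same on both cores stays unresolved, as compound 3 is recorded only as a limit: the limit of > 100000 nM in this assay, at which 1 of the 4 values shown sits. Phenyl in place of 3,4,5-trimethoxyphenyl on a carbonyl carbon gives a 1.4-fold lower number from compound 1 to compound 4 (0.16 log units; within the scatter), and two pairs in one assay establish no rule for the wider series.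

The compounds shown leave open whether a pyridin-2-yl or thiazol-2-yl group on the saturated ring carbon would follow furan-2-yl or thiophen-2-yl. They also leave open whether the furan-2-yl step would hold with an amine on the phenyl ring of the benzoyl group.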